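This account rests on a few compounds, and the source may have more. Where it says the series, first, only, none or still open, it means among the compounds named here.

Among the compounds with values here, in a functional assay on CHO cells for antagonist activity at Orexin receptor type 2 (Homo sapiens), read by FLIPR and calcium flux (a higher number here means a weaker inhibitor, a lower number a stronger inhibitor), compound 1 `CCc1nc(C(F)(F)F)c2n1CCN([C@@H](C(=O)NC)c1ccccc1)[C@H]2CCc1ccc(C(F)(F)F)cc1` gives 11 nM, the lowest of the three numbers measured so far. Compound 3 `CCc1nc(I)c2n1CCN([C@@H](C(=O)NC)c1ccccc1)C2CCc1ccc(C(F)(F)F)cc1` gives 23 nM, the nearest of the other two, and compound 2 `CCOc1nc(CC)n2c1C(CCc1ccc(C(F)(F)F)cc1)N([C@@H](C(=O)NC)c1ccccc1)CC2` gives 2750 nM, the furthest. Within the data shown here, the only one-place step among the measured compounds runs between those two: a 120-fold lower number from compound 2 to compound 3 (2.08 log units; beyond the scatter). The position that carries trifluoromethyl in compound 1 is the same one that carries ethoxy in compound 2 and iodo in compound 3, so that step is the one that bears on the change now considered. Compound 4 `CCc1nc(SC)c2n1CCN([C@@H](C(=O)NC)c1ccccc1)[C@H]2CCc1ccc(C(F)(F)F)cc1` differs from compound 1 in one place: methylsulfanyl in place of trifluoromethyl on an aromatic carbon. Among the measured compounds shown here, the ethoxy of compound 2 and the methylsulfanyl of compound 4 are both joined to the ring through a non-carbon atom, whereas iodo and trifluoromethyl are not, and the one step that exists shows how far apart two groups at this position can lie. A shift toward weaker inhibition is therefore expected for compound 4, though a smaller one than that step, as compound 3 shows that a group other than trifluoromethyl at this position can still give 23 nM. Compound 4 is expected to give 60 nM, in the range 15 nM to 300 nM, which would mean an estimated step of a 5.5-fold higher number from compound 1 to compound 4 (0.74 log units; beyond the scatter).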

Compound 4, half-maximal inhibitory concentration: 14 nM
Compound 4: middle estimate off by 4.3-fold (0.63 log units), on the high side, outside the stated range (below it).
By their numbers in this assay, from the lowest: compounds 1, 4 and 3 (each within the scatter of the next, the first and the last beyond it); then compound 2.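

In this assay, within the data shown here, methylsulfanyl in place of trifluoromethyl gives a 1.3-fold higher number from compound 1 to compound 4 (0.10 log units; within the scatter), so at this aromatic carbon the two groups cannot be told apart, something the earlier compounds could not show. Being joined to the ring through a non-carbon atom therefore does not by itself go with weak inhibition: compound 4 stays among the low numbers, while compound 2, with ethoxy at the same place, stands alone at 2750 nM, and the large step of a 120-fold lower number from compound 2 to compound 3 (2.08 log units; beyond the scatter) can no longer be read as a penalty on every group joined in that way. Nothing available explains why methylsulfanyl and ethoxy part so widely at this position, and the result is left without a cause.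

The compounds shown leave open whether methoxy or ethylsulfanyl would fall with methylsulfanyl or with ethoxy, which would separate the linking atom from the length of the chain. They also leave open how an amine or a nitrile on this aromatic carbon would read in this assay.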